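Swapping Methoxy for Dimethylamino on a Side Chain

This account rests on a few compounds, and the source may have more. Where it says the series, first, only, none or still open, it means among the compounds named here.

Of the compounds shown here, three with a shared core have been tested in a functional assay on DU-145 cells (Homo sapiens) for antiproliferative activity, read by sulforhodamine B assay, with a stated time of 3 days; a lower number here means a stronger inhibitor of growth, a higher number a weaker inhibitor of growth. Compound 1 `O=C(Nc1nccs1)c1cccc(Nc2ncc(F)c(Nc3ccc(F)cc3)n2)c1` gives > 10000 nM, which is a limit of the assay and not a number. Going by the values given here, compound 2 `O=C(Nc1cccc(Nc2ncc(F)c(Nc3ccc(F)cc3)n2)c1)c1cccc([N+](=O)[O-])c1` gives 12600 nM, and compound 3 `COCC(=O)Nc1cccc(Nc2ncc(F)c(Nc3ccc(F)cc3)n2)c1` gives 4460 nM, the lowest number so far and so the strongest growth inhibition of the three.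

The next molecule is compound 4 `CN(C)CC(=O)Nc1cccc(Nc2ncc(F)c(Nc3ccc(F)cc3)n2)c1`. It has dimethylamino in place of methoxy on a saturated chain carbon bound to a carbonyl carbon. Among the compounds with values here, two measured steps touch this part of the molecule. One, a 2.8-fold lower number from compound 2 to compound 3 (0.45 log units; beyond the scatter), came with methoxymethyl in place of 3-nitrophenyl on a carbonyl carbon. The other, an at least 2.2-fold lower number from compound 1 to compound 3 (0.35 log units; beyond the scatter), came with ((methoxymethyl)carbonyl)amino in place of (1,3-thiazol-2-yl)carbamoyl on an aromatic carbon, and it starts from a limit. Neither step tests the methoxy group itself, so the data favour no direction. Going by the modest size of a 2.8-fold lower number from compound 2 to compound 3 (0.45 log units; beyond the scatter), only a small change is expected here, quite possibly none beyond the scatter. The estimate amounts to an expected 1.1-fold lower number from compound 3 to compound 4 (0.05 log units; within the scatter). In this assay the expected value for compound 4 is 4000 nM, with a likely range from 1500 nM to 11000 nM.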

Compound 4, concentration for 50% growth inhibition: 1210 nM
The estimate for compound 4 lay 3.3-fold (0.52 log units) above the measured number; measured number below the stated range.
By their numbers in this assay, from the lowest: compound 4; then compound 3; then compound 2.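

In this assay, going by these compounds alone, dimethylamino in place of methoxy on a saturated chain carbon bound to a carbonyl carbon gives a 3.7-fold lower number from compound 3 to compound 4 (0.57 log units; beyond the scatter), so this position responds to the group it carries, something the earlier steps could not show because none of them changed the methoxy group alone. Measured against the 3-nitrophenyl group on the carbonyl carbon, (dimethylamino)methyl gives a 10-fold lower number from compound 2 to compound 4 (1.02 log units; beyond the scatter), a large step where methoxymethyl gave only a modest one. The comparison with the (1,3-thiazol-2-yl)carbamoyl group reads an at least 8.2-fold lower number from compound 1 to compound 4 (0.91 log units; beyond the scatter), but it starts from a limit, so its true size stays unknown: the limit of > 10000 nM in this assay, at which 1 of the 4 values shown sits.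

A single swap cannot tell whether the lower number goes with the nitrogen atom or with the larger group, and a primary amine, a carboxylic acid or a longer chain between the amine and the carbonyl at this position would help to separate the two. As far as these compounds go, whether the same swap lowers the number in other cell lines also remains open.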